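This account rests on a few compounds, and the source may have more. Where it says the series, first, only, none or still open, it means among the compounds named here.

Of the compounds shown here, three of a shared core have been measured in an assay for inhibition of inositol hexakisphosphate kinase 3 (Homo sapiens), read by colorimetric assay, coupled enzyme assay and malachite green, with a stated time of 120 min, in the presence of a further agent that is not named here; on this read-out lower numbers stand for stronger inhibition and higher numbers for weaker inhibition. Compound 1 `Cc1cccc(-c2onc3ccc(/C=C/C(=O)O)cc23)c1` gives 3590 nM, compound 2 `CNC(=O)c1ccc2noc(-c3ccccc3)c2c1` gives 6830 nM, and compound 3 `O=C(O)c1ccc2noc(-c3ccc(N4CCCCC4)cc3)c2c1` gives 1790 nM. Compound 3 thus carries the lowest of the three numbers: the gap to compound 1 lies within the usual scatter of such measurements, so no order between these two can be read, whereas the gap to compound 2 lies beyond it.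

The next compound, compound 4 `O=C(O)c1ccc2noc(-c3ccc(NC(=O)c4ccccc4)cc3)c2c1`, keeps the carboxylic acid of compound 3 and changes only the substituent on the pendant ring: benzamido in place of piperidin-1-yl on an aromatic carbon.

Among the compounds with values here, no measured pair in this set shows the effect of such a change, so the size of the step can only be guessed. Since the core and the acid are unchanged, he expects a step from compound 3 to compound 4 of a 1.1-fold higher number from compound 3 to compound 4 (0.05 log units; within the scatter), that is, no shift clearly beyond the scatter in either direction. For compound 4 in this assay he estimates 2000 nM, within a range from 600 nM to 6500 nM.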

Compound 4, half-maximal inhibitory concentration: 200 nM
Beside the measured number, compound 4's estimate is 10-fold (1.00 log units) above it; measured number outside the range, below it.
By their numbers in this assay, from the lowest: compound 4; then compounds 3, 1 and 2 (each within the scatter of the next, the first and the last beyond it).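

In this assay, benzamido in place of piperidin-1-yl gives a 9.0-fold lower number from compound 3 to compound 4 (0.95 log units; beyond the scatter), a step beyond the scatter. Within the data shown here, the earlier compounds held no measured pair that differed in one place, so this is the first evidence that the substituent on this aromatic carbon, para to a large group, can move the number markedly while the core and the carboxylic acid stay the same. Nothing at hand accounts for the size of this step.

Which part of benzamido goes with the step stays open: an acetamido or a cyclohexanecarboxamido group at this place would separate the outer aromatic ring from the amide, and a benzylamino group would test the carbonyl. Going by these compounds, whether the step holds when a methyl amide stands in place of the carboxylic acid also remains open.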